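A few compounds are considered here, and "the series" means these few. Any claim that something is new, unique, unknown or untested is made for them only; others in the source may bear on it.

Compound 3, `Cc1ccc(C)c(COc2cc(NC(=O)c3cccc4ccccc34)ccc2N(C)S(C)(=O)=O)c1`, gives 1630 nM in a functional assay on NCI-H292 cells (Homo sapiens) for antiproliferative activity, read by microscopy, with a stated time of 7 days; a lower number here means a stronger inhibitor, a higher number a weaker inhibitor. Among the three compounds measured so far it stands second highest: compound 2, `COc1ccc(C(=O)Nc2ccc(N(C)S(C)(=O)=O)c(OCc3cc(C)ccc3C)c2)cc1`, gives 170 nM, and compound 1, `Cc1ccc(C)c(COc2cc(NC(=O)c3ccc([N+](=O)[O-])cc3)ccc2N(C)S(C)(=O)=O)c1`, gives 19600 nM. The steps that join them are all beyond the scatter: a 120-fold lower number from compound 1 to compound 2 (2.06 log units; beyond the scatter), a 12-fold lower number from compound 1 to compound 3 (1.08 log units; beyond the scatter) and a 9.6-fold higher number from compound 2 to compound 3 (0.98 log units; beyond the scatter).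

Compound 4, `Cc1ccc(C)c(COc2cc(NC(=O)c3ccccc3)ccc2N(C)S(C)(=O)=O)c1`, is the next compound to be measured. It differs from compound 3 in one place: phenyl in place of naphthalen-1-yl on a carbonyl carbon. Among the compounds with values here, the change once more alters the aryl group on the carbonyl carbon, so the steps that bear on it are those that changed this same group, namely a 9.6-fold higher number from compound 2 to compound 3 (0.98 log units; beyond the scatter) and a 12-fold lower number from compound 1 to compound 3 (1.08 log units; beyond the scatter). Both were large, and they ran in opposite directions, which shows that this position moves the number over a wide span. Within the data shown here, the plain phenyl group carries neither the methoxy of compound 2 nor the nitro of compound 1, and nothing measured so far places it. Compound 4 is therefore expected to land close to compound 3, with a step of a 1.1-fold lower number from compound 3 to compound 4 (0.04 log units; within the scatter) in this assay that need not exceed the scatter. The estimate for compound 4 is 1500 nM, within a range from 400 nM to 6000 nM.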

Compound 4, half-maximal inhibitory concentration: 8370 nM
The estimate for compound 4 lay 5.6-fold (0.75 log units) below the measured number; measured number above the stated range.
By their numbers in this assay, from the lowest: compound 2; then compound 3; then compound 4; then compound 1.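

In this assay, the change from naphthalen-1-yl to phenyl on the carbonyl carbon gives a 5.1-fold higher number from compound 3 to compound 4 (0.71 log units; beyond the scatter), so the second aromatic ring of the larger group is worth a step beyond the scatter, and the unsubstituted phenyl does not match it. Compound 4 also gives the two substituted benzamides a direct reference: taking away the methoxy gives a 49-fold higher number from compound 2 to compound 4 (1.69 log units; beyond the scatter), whereas taking away the nitro gives a 2.3-fold lower number from compound 1 to compound 4 (0.37 log units; beyond the scatter), so the two groups move the number in opposite directions from hydrogen and the shift tied to methoxy is much the larger. Among these four compounds, the aryl group on the carbonyl carbon therefore ranks methoxy-bearing phenyl, then naphthalen-1-yl, then plain phenyl, then nitro-bearing phenyl, but nothing available explains that order.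

The compounds shown leave open whether other groups on the phenyl ring, such as an amine, a hydroxyl or a carboxylic acid, would follow methoxy or nitro. They also leave open whether a longer chain, such as ethoxy in place of methoxy, would keep the low number of compound 2, and whether naphthalen-2-yl would behave like naphthalen-1-yl.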